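Swapping the amine linker of compound 3 for an amide

A few compounds are considered here, and "the series" means these few. Any claim that something is new, unique, unknown or untested is made for them only; others in the source may bear on it.

Compound 1 `C=C1CC[C@@H]2[C@](C)(CNCc3ccc(OC)cc3)[C@H](O)CC[C@@]2(C)[C@@H]1/C=C/C1=CCOC1=O` gives 750 nM in a functional assay on BMMC cells (Mus musculus, strain C57BL/6) for inhibition, with stated times of 5 days and 48 h; a higher number here means a weaker inhibitor, a lower number a stronger inhibitor.
Compound 2 `C=C1CC[C@@H]2[C@](C)(CNCc3ccc(O)c(O)c3)[C@H](O)CC[C@@]2(C)[C@@H]1/C=C/C1=CCOC1=O` gives 9440 nM in this assay.
Compound 3 `C=C1CC[C@@H]2[C@](C)(CNCc3cccs3)[C@H](O)CC[C@@]2(C)[C@@H]1/C=C/C1=CCOC1=O` gives 1070 nM in this assay.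

Compound 3 holds the second highest of these three numbers: a 1.4-fold higher number from compound 1 to compound 3 (0.15 log units; within the scatter), whereas an 8.8-fold lower number from compound 2 to compound 3 (0.95 log units; beyond the scatter). Compound 4 `C=C1CC[C@H]2[C@@](C)(CC[C@@H](O)[C@@]2(C)C(=O)NCc2ccccc2)[C@@H]1/C=C/C1=CCOC1=O` differs from compound 3 by benzylcarbamoyl in place of (((thiophen-2-yl)methyl)amino)methyl on a saturated ring carbon. Every measured step changes only the aromatic group at the end of the amine, for example a 13-fold higher number from compound 1 to compound 2 (1.10 log units; beyond the scatter); none changes the linker itself, so there is no direct guide for this step. As far as these compounds go, the benzyl group of compound 4 resembles the groups of compounds 1 and 3 rather than that of compound 2, but the amide is untested, so a modest weakening is expected, a 2.3-fold higher number from compound 3 to compound 4 (0.37 log units; beyond the scatter). Compound 4 is expected to give 2500 nM in this assay, within 600 nM to 10000 nM.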

Compound 4, half-maximal inhibitory concentration: 19400 nM
Compound 4: the middle estimate sits 7.8-fold (0.89 log units) below what was measured; the measured number lies above the stated range.
By their numbers in this assay, from the lowest: compounds 1 and 3 (each within the scatter of the next); then compound 2; then compound 4.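

In this assay the benzylcarbamoyl group at this saturated ring carbon gives a clear loss against the thiophene amine (an 18-fold higher number from compound 3 to compound 4 (1.26 log units; beyond the scatter)) and against the 4-methoxybenzyl amine (a 26-fold higher number from compound 1 to compound 4 (1.41 log units; beyond the scatter)). The smaller step from the dihydroxy amine (a 2.1-fold higher number from compound 2 to compound 4 (0.31 log units; beyond the scatter)) still leaves compound 4 with the highest number of the four. Nothing shown here explains this loss.

As far as these compounds go, compound 4 changes the linker and the aromatic group together, so the share of each in the loss stays open. A (benzylamino)methyl group at this carbon would separate the two.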